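One More Methyl on the Chain: Compound 4 Awaits

The source may report more compounds than this note shows. Statements on the series, on what has been measured and on what is new or still open speak of the compounds shown alone.

Of the compounds shown here, three of this cytotoxicity study have been measured and a fourth has not. Compound 1 `CCCCOc1ccc(O)c(C(=O)/C=C/c2ccc(C)s2)c1` gives 38900 nM in a functional assay on MCF7 cells (Homo sapiens) for cytotoxicity, read by MTT assay; on this read-out lower numbers stand for stronger inhibition and higher numbers for weaker inhibition. Compound 2 `CCCCCOc1ccc(O)c(C(=O)/C=C/c2ccc(C)s2)c1` differs from compound 1 only by methyl in place of hydrogen on a saturated chain carbon, four bonds along the chain from an oxygen on an aromatic ring, and in this assay compound 2 gives 48400 nM. The step between them, a 1.2-fold higher number from compound 1 to compound 2 (0.09 log units; within the scatter), is therefore no real movement. Compound 3 `CCOc1ccc(OC)cc1C(=O)/C=C/c1ccc(C)s1` stands on a different core; the difference between the two cores is not broken down here. In this assay compound 3 gives 2300 nM, the lowest of the three numbers, and its steps to compound 1 and to compound 2 are both beyond the scatter.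

Compound 4 `CCCOc1ccc(OC)cc1C(=O)/C=C/c1ccc(C)s1` carries, relative to compound 3, (methyl in place of hydrogen on a saturated chain carbon, two bonds along the chain from an oxygen on an aromatic ring). Among the measured compounds shown here, this is the same kind of change as the one from compound 1 to compound 2, though not the same: there the methyl entered four bonds along the chain from an oxygen on an aromatic ring, here it enters two bonds along the chain from an oxygen on an aromatic ring. Only one earlier instance of this kind of change exists among these compounds, and it sits on the other core.

The step expected from compound 3 to compound 4 is a 1.2-fold higher number from compound 3 to compound 4 (0.09 log units; within the scatter), an expectation that rests on the fact that a 1.2-fold higher number from compound 1 to compound 2 (0.09 log units; within the scatter) stayed within the scatter. Compound 4 is accordingly estimated at 2800 nM, with a plausible range from 1200 nM to 7000 nM. Whether a single added methyl behaves the same way on the core of compound 3 is what the coming measurement will tell.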

Compound 4, half-maximal inhibitory concentration: 800 nM
For compound 4 the middle estimate is 3.5-fold (0.54 log units) above the measured one, and the stated range ends above it.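

In this assay, adding the methyl to the core of compound 3 gave a 2.9-fold lower number from compound 3 to compound 4 (0.46 log units; beyond the scatter), so the change from ethoxy to propoxy moved the number on this core, whereas the earlier methyl addition on the core of compound 1 stayed within the scatter. The two steps therefore cannot be treated as one transferable effect of adding a methyl to the chain: the same change on two cores in this assay, a 1.2-fold higher number (0.09 log units; within the scatter) from compound 1 to compound 2 and a 2.9-fold lower number (0.46 log units; beyond the scatter) from compound 3 to compound 4, 3.6-fold (0.55 log units) apart, beyond the scatter of two such steps. This does not show that the core alone decides the outcome: the methyl enters two bonds along the chain from an oxygen on an aromatic ring in one pair and four bonds along it in the other, and with a single pair on each core, the influence of the core cannot be separated from that of the place.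

The compounds shown leave open whether a longer chain on the core of compound 3 would continue the downward step seen with propoxy or reverse it, and whether an amine or a carboxylic acid at the end of that chain would be tolerated. They also leave open how the change from ethoxy to propoxy would behave on the core of compound 1.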